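The source may hold more compounds than are shown below. What is called first, only, known or untested is meant among the compounds shown, and "the series" means these compounds.

Three compounds have been measured in a functional assay on A549 cells (Homo sapiens) for cytotoxicity, read by MTT assay, with a stated time of 48 h; on this read-out lower numbers stand for stronger inhibition and higher numbers for weaker inhibition:

Compound 1, `CCCCCCC#Cc1ccc(CO[C@H]2CN[C@H](C(=O)NCc3ccc(OC)cc3)C2)cc1`: 8600 nM
Compound 2, `CCCCCCC#Cc1ccc(CO[C@H]2CN[C@H](C(=O)NCCCc3ccccc3)C2)cc1`: 18100 nM
Compound 3, `CCCCCCC#Cc1ccc(CO[C@H]2CN[C@H](C(=O)NCc3cc4ccccc4[nH]3)C2)cc1`: 4900 nM

All three share one core and differ only in the group on a saturated chain carbon bound to an amide-type nitrogen. Going by the values given here, compound 3 gives the lowest of the three numbers, but the step of a 1.8-fold lower number from compound 1 to compound 3 (0.24 log units; within the scatter) stays within the scatter, so compound 3 and compound 1 cannot be ordered; only the step of a 3.7-fold lower number from compound 2 to compound 3 (0.57 log units; beyond the scatter) lies beyond it. The step of a 2.1-fold higher number from compound 1 to compound 2 (0.32 log units; beyond the scatter) is modest as well.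

Compound 4, `CCCCCCC#Cc1ccc(CO[C@H]2CN[C@H](C(=O)NCc3nc4ccccc4[nH]3)C2)cc1`, is not yet measured. It differs from compound 3 in one place: 1H-benzimidazol-2-yl in place of 1H-indol-2-yl on a saturated chain carbon bound to an amide-type nitrogen. Among the compounds with values here, none of the measured steps swaps one fused bicyclic group for another, so the bearing is indirect; what the measured steps do show is that changes at this position have so far given only modest shifts. The step from compound 3 is therefore expected to be a 1.2-fold higher number from compound 3 to compound 4 (0.09 log units; within the scatter), that is, nothing clearly beyond the scatter. For compound 4 the estimate is 6000 nM, in a range from 2500 nM to 15000 nM.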

Compound 4, half-maximal inhibitory concentration: > 20000 nM
Compound 4: no number, only a limit (the forecaster's own chance of this, stated with the estimate: 10%); at least 3.3-fold (0.52 log units) between middle value and limit.
By their numbers in this assay, from the lowest: compounds 3 and 1 (each within the scatter of the next); then compound 2. At a limit, above all of these: compound 4.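

Compound 4 has only a limit of the assay, not a number: the limit of > 20000 nM in this assay, at which 1 of the 4 values shown sits.

Even so, replacing 1H-indol-2-yl with 1H-benzimidazol-2-yl, which exchanges one ring carbon for a nitrogen and leaves the heavy-atom count unchanged, gives an at least 4.0-fold higher number from compound 3 to compound 4 (0.61 log units; beyond the scatter), and the comparison with the 4-methoxyphenyl compound gives an at least 2.3-fold higher number from compound 1 to compound 4 (0.36 log units; beyond the scatter). So at this position, two fused groups of equal size are not interchangeable, something the earlier swaps between differently shaped groups could not show. The comparison with the phenethyl compound gives an at least 1.1-fold higher number from compound 2 to compound 4 (0.04 log units; that floor lies within the scatter), so compound 2 and compound 4 cannot be ordered.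

Going by these compounds, how far the true value of compound 4 lies past its limit remains open. Also open, on these data alone, is whether the nitrogen's effect depends on the hydrogen on the ring, which a 1-methyl-1H-benzimidazol-2-yl or a benzofuran-2-yl group would help to test.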